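This account rests on a few compounds, and the source may have more. Where it says the series, first, only, none or still open, it means among the compounds named here.

Compound 1 `COC(=O)c1cc(C2=C(c3cc(OC)c(OC)c(OC)c3)C(=O)CC2O[SiH2]C(C)(C)C)ccc1OC` bears a methoxycarbonyl group on an aromatic carbon of the shared core. In an ADME assay on ECV-304 cells (Homo sapiens) for cytotoxicity, read by MTT assay, with a stated time of 72 h (on this read-out lower numbers stand for stronger inhibition and higher numbers for weaker inhibition), compound 1 gives > 100 ug/mL, which is a limit of the assay and not a number. Compound 3 `CCOC(=O)COc1ccc(C2=C(c3cc(OC)c(OC)c(OC)c3)C(=O)CC2O)cc1` gives > 100 ug/mL in this assay, again a limit. For compound 2 `COc1ccc(C2=C(c3cc(OC)c(OC)c(OC)c3)C(=O)CC2OC(C)=O)cc1NC=O` the result in this assay is "not determined" (no result reported). Compound 1 therefore sits at the limit of > 100 ug/mL in this assay, at which 2 of the 3 values shown sit, with no single number to rank it. Compound 4 `COc1ccc(C2=C(c3cc(OC)c(OC)c(OC)c3)C(=O)CC2O[SiH2]C(C)(C)C)cc1O` differs from compound 1 by hydroxy in place of methoxycarbonyl on an aromatic carbon. Within the data shown here, no step between measured compounds exists, so the size of this change is unknown; with compound 1 at the limit, no shift beyond the scatter is expected. Compound 4 is expected at 100 ug/mL, between 40 ug/mL and 200 ug/mL. The expected step of a number no higher from compound 1 to compound 4 (the limit leaves the size open) is thus within the scatter.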

Compound 4, half-maximal inhibitory concentration: 30 ug/mL
Compound 4: middle estimate off by 3.3-fold (0.52 log units), on the high side; the measured number lies below the stated range.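

In this assay, hydroxy in place of methoxycarbonyl on this aromatic carbon gives an at least 3.3-fold lower number from compound 1 to compound 4 (0.52 log units; beyond the scatter). From the compounds shown here alone, compound 1 stands at > 100 ug/mL, which is a limit and not a number, so the size of the step stays open on one side. Compound 4 is the only compound shown with a single number, and the read-out at this position is now seen to move off the limit: the limit of > 100 ug/mL in this assay, at which 2 of the 4 values shown sit.

Going by these compounds, whether an amine or a carboxylic acid on the same aromatic carbon would also leave the limit stays open. One step also cannot say whether this change would carry over with other groups elsewhere on the shared core.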